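A Sulfonyl in Place of Acetyl on a Shared Core

The source may hold more compounds than are shown below. What is called first, only, known or untested is meant among the compounds shown, and "the series" means these compounds.

Compound 1 `CC(=O)N(C)c1ccc2[nH]c(-c3n[nH]c4ccccc34)cc2n1` was tested in a functional assay on KB cells (Homo sapiens) for antiproliferative activity, read by MTT assay, with a stated time of 72 h (on this read-out higher numbers stand for weaker inhibition and lower numbers for stronger inhibition), where compound 1 gives 10300 nM, the highest of the three numbers recorded. Compound 2 `COc1cccc(C(=O)N(C)c2ccc3[nH]c(-c4n[nH]c5ccccc45)cc3n2)c1` gives 9010 nM, and the step of a 1.1-fold lower number from compound 1 to compound 2 (0.06 log units; within the scatter) stays within the scatter. Compound 3 `CN(c1ccc2[nH]c(-c3n[nH]c4ccccc34)cc2n1)S(=O)(=O)c1ccccc1` gives 2400 nM; the step of a 4.3-fold lower number from compound 1 to compound 3 (0.63 log units; beyond the scatter) is modest but beyond the scatter, as is a 3.8-fold lower number from compound 2 to compound 3 (0.57 log units; beyond the scatter). Compound 4 `CN(c1ccc2[nH]c(-c3n[nH]c4ccccc34)cc2n1)S(=O)(=O)c1ccc(Cl)cc1` differs from compound 1 by (4-chlorophenyl)sulfonyl in place of acetyl on a nitrogen on an aromatic ring. The step of a 4.3-fold lower number from compound 1 to compound 3 (0.63 log units; beyond the scatter) is the one that bears on this change, both exchanges removing acetyl for a sulfonyl group. The chlorine has no measured counterpart among these compounds. A step of similar size in the same direction is therefore expected: a 4.7-fold lower number from compound 1 to compound 4 (0.67 log units; beyond the scatter). Compound 4 is estimated at 2200 nM, with a range from 700 nM to 7000 nM.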

Compound 4, half-maximal inhibitory concentration: 8350 nM
Estimate against measurement, compound 4: 3.8-fold (0.58 log units) below; the measured number lies above the stated range.
By their numbers in this assay, from the lowest: compound 3; then compounds 4, 2 and 1 (each within the scatter of the next).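

The sulfonyl group on this nitrogen does not by itself bring the lower number of compound 3: with the chloro present, a 1.2-fold lower number from compound 1 to compound 4 (0.09 log units; within the scatter) and a 1.1-fold lower number from compound 2 to compound 4 (0.03 log units; within the scatter) leave compound 4 level with both amides. The chloro in place of hydrogen on an aromatic carbon is what matters here, giving a 3.5-fold higher number from compound 3 to compound 4 (0.54 log units; beyond the scatter) in this assay and cancelling the sulfonyl gain. Nothing available explains this reversal.

As far as these compounds go, whether the reversal is particular to chloro remains open. An amine or a carboxylic acid on that aromatic carbon could show whether other groups there behave alike.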